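The source may report more compounds than this note shows. Statements on the series, on what has been measured and on what is new or still open speak of the compounds shown alone.

Measured in a physicochemical assay for lipophilicity, measured as octanol-water partition, at pH 2; on this read-out lower numbers stand for lower lipophilicity and higher numbers for higher lipophilicity:
- Compound 1 (`CCCOC(=O)[C@@H](N)CCC(=O)NCCSC(C)=O`) gives 0.21
- Compound 2 (`CCCCOC(=O)[C@@H](N)CCC(=O)NCCSC(C)=O`) gives 0.43

Within the data shown here, compound 2 stands within the scatter of compound 1, the only other compound measured. Compound 3 (`CCOC(=O)[C@@H](N)CCC(=O)NCCSC(C)=O`) has hydrogen in place of ethyl on a saturated chain carbon, two bonds along the chain from an oxygen next to a carbonyl group. Among the measured compounds shown here, one measured step bears on this, a methyl added on the same chain (a number 0.22 log units higher from compound 1 to compound 2 (within the scatter)). Butyl to ethyl removes more of the chain than that methyl added, so roughly two such steps downward are expected, though this rests on one small step. The expected change is a number 0.43 log units lower from compound 2 to compound 3 (beyond the scatter) on this estimate. Compound 3 is estimated at 0 with an expected range (-0.25 to 0.25).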

Compound 3, partition coefficient: 0.11
Compound 3: middle estimate off by 0.11 log units, on the low side; measured number inside the range.
By their numbers in this assay, from the lowest: compounds 3, 1 and 2 (each within the scatter of the next, the first and the last beyond it).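

Among these compounds, putting hydrogen in place of ethyl at this chain carbon gives a number 0.32 log units lower from compound 2 to compound 3 (beyond the scatter), the first step to clear the scatter in this assay. Hydrogen in place of methyl at the same place gives only a number 0.10 log units lower from compound 1 to compound 3 (within the scatter), so here only the larger cut to the chain can be told apart from noise. Nothing available explains these numbers. Still open, on these data alone, is whether a longer chain, such as hexyl, would continue this trend, and what a free carboxylic acid would give in place of the ester.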